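The source may hold more compounds than are shown below. What is called first, only, known or untested is meant among the compounds shown, and "the series" means these compounds.

Working notes on the hydroxamic acid series in a functional assay on NCI-H23 cells (Homo sapiens) for inhibition, read by sulforhodamine B assay; a lower number here means a stronger inhibitor of growth, a higher number a weaker inhibitor of growth.

Three analogues carry the same core and the same three-carbon chain to an aryl group; they differ only in the aryl substituent. Compound 1 `O=C(CCC1=CCN(CCCc2ccc(Cl)cc2)C1=O)NO` gives 2520 nM in this assay. Compound 2 `CC(C)(C)c1ccc(CCCN2CC=C(CCC(=O)NO)C2=O)cc1` gives 2520 nM. Compound 3 `Cc1cccc(CCCN2CC=C(CCC(=O)NO)C2=O)c1` gives 2520 nM. The change from compound 1 to compound 2 is no change at the digits printed from compound 1 to compound 2 (within the scatter), and the change from compound 1 to compound 3 is no change at the digits printed from compound 1 to compound 3 (within the scatter). Compound 3 therefore stands level with compounds 1 and 2 at the digits shown; none of the three can be called stronger or weaker than another on these numbers.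

Compound 4 `Cc1ccc(CCCN2CC=C(CCC(=O)NO)C2=O)cc1` is not yet measured in this assay. Compound 4 differs from compound 3 as follows: 4-methylphenyl in place of 3-methylphenyl on a saturated chain carbon, three bonds along the chain from an amide-type nitrogen in a ring.

Both measured steps bear on this: each swapped one aryl substituent for another at the same place on the chain, and each came out within the scatter. The step from compound 3 to compound 4 is a smaller change in kind than either of those, so no change beyond the scatter is expected in this assay, with no change at the digits printed from compound 3 to compound 4 (within the scatter) as the expected step. For compound 4 the estimate in this assay is 2520 nM, expected to fall between 1260 nM and 5040 nM.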

Compound 4, concentration for 50% growth inhibition: 2520 nM
Compound 4: the middle estimate sits on the measured number at the digits printed; the range from low to high includes it.
By their numbers in this assay, from the lowest: compounds 1, 2, 3 and 4 (each within the scatter of the next).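

In this assay, among the compounds shown here, exchanging 3-methylphenyl for 4-methylphenyl on the saturated chain carbon gives no change at the digits printed from compound 3 to compound 4 (within the scatter) and is the first step here that alters only where a substituent sits on the aryl group, with the atoms unchanged. The two further steps extend the comparison to the substituent itself: methyl in place of tert-butyl on an aromatic carbon gives no change at the digits printed from compound 2 to compound 4 (within the scatter) and methyl in place of chloro on an aromatic carbon gives no change at the digits printed from compound 1 to compound 4 (within the scatter) so that, across these four compounds, neither the identity of these substituents nor this change in methyl placement separates the growth-inhibition values. No supporting measurement is available to account for this flat result.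

The compounds shown leave open whether an aryl group carrying an amine or a carboxylic acid would read differently from these hydrocarbon and chloro substituents in this assay. They also leave open whether a longer chain between the amide-type ring nitrogen and the aryl group, or an unsubstituted phenyl at the chain end, would depart from this level.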